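The source may report more compounds than this note shows. Statements on the series, on what has been measured and on what is new or still open speak of the compounds shown alone.

Measured compounds in a functional assay on HT-29 cells (Homo sapiens) for cytotoxicity, read by sulforhodamine B assay; a higher number here means that more compound is tolerated, a lower number that less compound is tolerated:
- compound 1 `COc1ccc(/C=N\NC(=S)NC(C)(C)CCC[C@](C)(O)[C@@H]2CC=C(C)CC2)cc1`; its value is a limit of the assay, > 100000 nM
- compound 2 `CC1=CC[C@@H]([C@@](C)(O)CCCC(C)(C)NC(=S)N/N=C\c2cccc([N+](=O)[O-])c2)CC1`; its value is also a limit of the assay, > 100000 nM

Compound 2 thus stands at the limit of this assay, with no number of its own. The step that the two limits leave unreadable from compound 1 to compound 2 cannot be read, as both ends sit at the limit of > 100000 nM in this assay, at which 2 of the 2 values shown sit.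

Compound 3 `CC1=CC[C@@H]([C@@](C)(O)CCCC(C)(C)NC(=S)N/N=C\c2ccccc2Cl)CC1` is not yet measured. It differs from compound 2 in one place: 2-chlorophenyl in place of 3-nitrophenyl on a carbon with a double bond to nitrogen. Among the compounds with values here, the only measured step that bears on this position is the unreadable one, so no size or direction of change in this assay can be derived from it; the expectation rests on both measured values sitting at the limit. Compound 3 is therefore expected to give 120000 nM, within 40000 nM to 300000 nM, most likely again as a limit only. The step this estimate implies is a step that the limit leaves unreadable from compound 2 to compound 3, expected to be no more than the scatter.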

Compound 3, concentration lethal to 50% of the cells: > 100000 nM
Compound 3: no number, only a limit; the forecaster's own chance of this, stated with the estimate: 70%; the middle value lies beyond the limit too.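

In this assay compound 3 gives only a limit, > 100000 nM. Within the data shown here, no step among compound 1, compound 2 and compound 3 can be read, as all three sit at the same limit: the limit of > 100000 nM in this assay, at which 3 of the 3 values shown sit.

Left open is whether 4-methoxyphenyl, 3-nitrophenyl and 2-chlorophenyl differ at all in cytotoxicity; the compounds shown give no number for any of them.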